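The source may hold more compounds than are shown below. What is called first, only, known or untested is meant among the compounds shown, and "the series" means these compounds.

Compound 1 `Cc1ccccc1-n1nncc1CN1C(=O)C2(C(C#N)=C(N)Oc3c2c2nc4ccccc4nc2c2ccccc32)c2ccccc21` — in a functional assay on HCT-116 cells (Homo sapiens) for antiproliferative activity, read by MTT assay, with a stated time of 48 h (a lower number here means a stronger inhibitor, a higher number a weaker inhibitor), compound 1 gives > 50000 nM, a limit of the assay and not a number.
Compound 2 `COc1ccc(-n2nncc2CN2C(=O)C3(C(C#N)=C(N)Oc4c3c3nc5ccccc5nc3c3ccccc43)c3ccccc32)cc1` — in this assay compound 2 gives > 50000 nM, again a limit of the assay.
Compound 3 `CC(=O)Nc1ccc(-n2nncc2CN2C(=O)C3(C(C#N)=C(N)Oc4c(N)cc5nc6ccccc6nc5c43)c3ccccc32)cc1` — in this assay compound 3 gives > 50000 nM, also a limit of the assay.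

Compound 3 therefore stands where every measured compound of this set stands, at the limit of > 50000 nM in this assay, at which 3 of the 3 values shown sit. Among the measured compounds shown here, the one step between measured compounds that differ in a single place, a step that the two limits leave unreadable from compound 1 to compound 2, cannot be read because both of its ends sit at the limit of > 50000 nM in this assay, at which 3 of the 3 values shown sit; it says nothing about size or direction.

Compound 4 `Cc1ccc(Cl)cc1-n1nncc1CN1C(=O)C2(C(C#N)=C(N)Oc3c(N)cc4nc5ccccc5nc4c32)c2ccccc21` differs from compound 3 in one place: 5-chloro-2-methylphenyl in place of 4-acetamidophenyl on an aromatic nitrogen. For the measured compounds named here, no measured step bears on this particular change, and no measured value in this assay is a number, so no step of any size beyond the scatter can be expected from the data in either direction. The only expectation the three limits support is that compound 4 stays at the limit as well.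

Compound 4 is thus expected at 50000 nM, with a range from 20000 nM to 150000 nM. The step of a number no higher from compound 3 to compound 4 (the limit leaves the size open) is estimated to be flat, within the scatter.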

Compound 4, half-maximal inhibitory concentration: 37200 nM
Compound 4: the middle estimate sits 1.3-fold (0.13 log units) above what was measured; measured number inside the range.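

In this assay, among the compounds shown here, compound 4 is the only compound of the set to give a number and not a limit, so the aryl group on the aromatic nitrogen of the five-membered ring is the first place where a change comes with a readable value: the limit of > 50000 nM in this assay, at which 3 of the 4 values shown sit. From the compounds shown here alone, putting 5-chloro-2-methylphenyl in place of 4-acetamidophenyl gives an at least 1.3-fold lower number from compound 3 to compound 4 (0.12 log units; that floor lies within the scatter) and the true size stays open, as the compound 3 end of the step is a limit. For the compounds shown here, the one earlier step, between compound 1 and compound 2, cannot be read, so this floor is the only sign of direction at this position, and it does not by itself establish a step beyond the scatter.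

The compounds shown leave open whether the chlorine or the methyl of the 5-chloro-2-methylphenyl group goes with the measured number, as no compound here carries one of them without the other on this core. Also open, going by these compounds, is how an aryl group bearing an amine or a carboxylic acid, or a longer alkyl chain in place of the aryl group, would read at this position in this assay.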